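This account rests on a few compounds, and the source may have more. Where it says the series, first, only, none or still open, it means among the compounds named here.

Measured compounds:
Compound 1 `O=C(CN(c1nc(Cl)nc2[nH]cnc12)C1CC1)N[C@@H](CO)C(=O)OCc1ccccc1` in a functional assay on the whole organism (Tail, strain ICR) with Mus musculus as the target, in the tail flick test, with a stated time of 90 min, at a dose of 25 umol/kg by the oral route (on this read-out higher numbers stand for a stronger effect at the one dose given and lower numbers for a weaker effect), gives 34.5%
Compound 2 `NC(=O)CC[C@H](NC(=O)CN(c1ncnc2c1ncn2C1CCCCO1)C1CC1)C(=O)OCc1ccccc1` gives 37.8%
Compound 3 `NCCCC[C@H](NC(=O)CN(c1nc(Cl)nc2[nH]cnc12)C1CC1)C(=O)OCc1ccccc1` gives 35.3%

For the measured compounds named here, all three numbers sit close together; compound 2 does not separate from compound 3 or from compound 1 beyond the scatter, so nothing among the measured set distinguishes one side chain from another. Going by the values given here, the one single-point comparison available is a number 0.8 percentage points higher from compound 1 to compound 3 (within the scatter), a change on the same saturated chain carbon that leaves the read-out where it was.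

Compound 4 `C[C@H](NC(=O)CN(c1ncnc2c1ncn2C1CCCCO1)C1CC1)C(=O)OCc1ccccc1` differs from compound 2 by hydrogen in place of carbamoylmethyl on a saturated chain carbon, two bonds along the chain from an amide-type nitrogen and a carbonyl carbon. It is a change at the same place as the step from compound 1 to compound 3, though it removes a group rather than exchanging one. Among the compounds with values here, with only that comparison to lean on, and it lying within the scatter, no step beyond the scatter is expected here in either direction; the step from compound 2 is estimated as a number 2.8 percentage points lower from compound 2 to compound 4 (within the scatter). Compound 4 is therefore expected to give 35%, with a range from 24% to 46%.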

Compound 4, a percentage reported as activity, at one dose (the size of the read-out at that dose, not a potency): 32.1%
The estimate for compound 4 lay 2.9 percentage points above the measured number, within the range that was stated.
By their numbers in this assay, from the lowest: compounds 4, 1, 3 and 2 (each within the scatter of the next).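

In this assay, hydrogen in place of carbamoylmethyl on the saturated chain carbon gives a number 5.7 percentage points lower from compound 2 to compound 4 (within the scatter), so compound 4 shows that this side chain can be removed without a step beyond the scatter. For the compounds shown here, until now, the only comparison at this place was an exchange of one group for another, a number 0.8 percentage points higher from compound 1 to compound 3 (within the scatter); a removal now gives the same reading, and neither step ties the read-out to the group on this carbon. No measurement is at hand that bears on this result.

Going by these compounds, whether a carboxylic acid at the end of the side chain, or a benzyl group on the same carbon, would move the read-out beyond the scatter stays open. On these data alone, with a single dose and a single time, a difference between these compounds at other doses or times also stays open.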